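The source may hold more compounds than are shown below. What is called first, only, known or untested is meant among the compounds shown, and "the series" means these compounds.

Among the measured compounds shown here, compound 2 `C=CCn1c(=O)/c(=C\c2cccc(F)c2)[nH]c(=O)/c1=C\c1ccccc1OC` is the only member of this small set with a numeric result: in a functional assay on MCF7 cells (Homo sapiens) for cytotoxicity, read by CCK-8 assay, with a stated time of 72 h (a higher number here means a weaker inhibitor, a lower number a stronger inhibitor), compound 2 gives 13700 nM. Compound 1 `COc1ccccc1/C=c1/[nH]c(=O)/c(=C\c2cccc(Cl)c2Cl)[nH]c1=O` was tested as well, and in this assay compound 1 gives "not active" (no number reported), so compound 2 stands alone on the numbers shown. Compound 3 `C=CCn1c(=O)/c(=C\c2ccc(Cl)c(Cl)c2)[nH]c(=O)/c1=C\c1ccccc1OC` has not been measured; it carries 3,4-dichlorophenyl in place of 3-fluorophenyl on a double-bonded chain carbon bound to an aromatic carbon. For the measured compounds named here, with no comparable step among the measured compounds, no shift beyond the usual scatter is expected in either direction. The step of a 1.1-fold higher number from compound 2 to compound 3 (0.04 log units; within the scatter) is expected to stay small. Compound 3 is estimated at 15000 nM, with a range from 5000 nM to 50000 nM.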

Compound 3, half-maximal inhibitory concentration: "not active" (no number reported)
Compound 3: no number reported; there is nothing to compare the estimate with.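

In this assay compound 3 gives "not active" (no number reported), so no step from compound 2 can be read, and nothing shown bears on this result. The compounds shown leave open how far 3,4-dichlorophenyl in place of 3-fluorophenyl changes the potency.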